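Benzyl for thiophen-2-yl at the assay limit

This account rests on a few compounds, and the source may have more. Where it says the series, first, only, none or still open, it means among the compounds named here.

Values in an ADME assay on HEK-293T cells (Homo sapiens) for inhibition, read by CCK-8 assay, with a stated time of 48 h (on this read-out higher numbers stand for weaker inhibition and lower numbers for stronger inhibition), each one a limit and not a number:
compound 1 `Cc1ccc(S(=O)(=O)Oc2ccccc2/C=C(\C#N)C(=O)Nc2nnc(C)s2)cc1`: > 20000 nM
compound 2 `COc1ccc(S(=O)(=O)Oc2ccccc2/C=C(\C#N)C(=O)Nc2nnc(-c3cccs3)s2)cc1`: > 20000 nM
compound 3 `CC(=O)Nc1ccc(S(=O)(=O)Oc2cccc(/C=C(\C#N)C(=O)Nc3nnc(-c4cccs4)s3)c2)cc1`: > 20000 nM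

Compound 2 has no measured number, and its > 20000 nM is a limit. The set as a whole offers nothing else: the limit of > 20000 nM in this assay, at which 3 of the 3 values shown sit.

Compound 4 `COc1ccc(S(=O)(=O)Oc2ccccc2/C=C(\C#N)C(=O)Nc2nnc(Cc3ccccc3)s2)cc1` carries benzyl in place of the thiophen-2-yl of compound 2: benzyl in place of thiophen-2-yl on an aromatic carbon. Among the compounds with values here, no measured pair differs in one place, so the expectation rests on compound 2 and its limit of > 20000 nM. In this assay no step beyond the scatter is expected, in either direction. The expected change is a step that the limit leaves unreadable from compound 2 to compound 4. For compound 4 the estimate is 25000 nM, with an expected range of 10000 nM to 60000 nM.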

Compound 4, half-maximal inhibitory concentration: > 50000 nM
Compound 4: only a limit was reported; the forecaster's own chance of this, stated with the estimate: 80%; middle value at least 2.0-fold (0.30 log units) from the limit.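

In this assay compound 2 gives > 20000 nM, a limit. Compound 4 gives > 50000 nM, also a limit, so no step can be read between compound 2 and compound 4. The compounds shown leave open whether benzyl in place of thiophen-2-yl changes inhibition at all.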